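From cyclobutyl to oxan-4-yl on the carbonyl carbon

The source may hold more compounds than are shown below. What is called first, only, known or untested is meant among the compounds shown, and "the series" means these compounds.

In an ADME assay on microsomes (Homo sapiens) for metabolic stability (a lower number here means that the compound disappears faster, a higher number that the compound lasts longer), compound 2 (`O=C(C1CCC1)N1N=CCC1c1ccccc1`) gives 1.38 h, the only figure in this small series that is a number rather than a limit. Compound 1 (`CC(C)C(=O)N1N=CCC1c1ccccc1`) gives > 1.5 h, which is a limit. Compound 3 (`CC(=O)N1CCC(C(=O)N2N=CC[C@H]2c2ccccc2)CC1`) gives > 2.75 h, which is also a limit.

The next structure is compound 4 (`O=C(C1CCOCC1)N1N=CCC1c1ccccc1`), with oxan-4-yl in place of cyclobutyl on a carbonyl carbon.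

Within the data shown here, only one measured step involves a change at this carbonyl carbon: an at least 1.0-fold lower number from compound 1 to compound 2 (0.03 log units; that floor lies within the scatter). It puts cyclobutyl in place of isopropyl, and as a floor it leaves the true size of the step open. Among the measured compounds shown here, no measured step links compound 3 to compound 2, and their two values show only a limit and a number. For the measured compounds named here, there is thus no precedent for a large effect from a change at this place. Going by the values given here, with compound 2 at 1.38 h as the starting point and the step of an at least 1.0-fold lower number from compound 1 to compound 2 (0.03 log units; that floor lies within the scatter) as the only guide, no move beyond the scatter is expected in this assay, with any drift more likely towards a longer half-life.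

The expected step is a 1.4-fold higher number from compound 2 to compound 4 (0.16 log units; within the scatter). For compound 4 the estimate is 2 h, with an expected range of 1 h to 4 h. A limit instead of a number is also possible for compound 4.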

Compound 4, half-life: > 1.5 h
Compound 4: no number, only a limit (the forecaster's own chance of this, stated with the estimate: 45%); the middle value is on the limit's open side.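

Oxan-4-yl on the carbonyl carbon is a six-membered non-aromatic ring with 1 hetero atom, and in this assay compound 4 gives > 1.5 h, which is a limit and not a number. Unlike the earlier swap of isopropyl for cyclobutyl, this change brings in a hydrogen-bond acceptor, and it gives an at least 1.0-fold higher number from compound 2 to compound 4 (0.03 log units; that floor lies within the scatter), so no move beyond the scatter can be claimed, while the true size of the step stays open. The step from isopropyl to oxan-4-yl cannot be read, because compound 1 and compound 4 sit at one limit: the limit of > 1.5 h in this assay, at which 2 of the 4 values shown sit.

Going by these compounds, whether oxan-4-yl truly gives a longer half-life than cyclobutyl stays open as long as compound 4 has only a limit. Also open, on these data alone, is how an amine such as piperidin-4-yl, or a longer chain such as n-butyl, would read on this carbonyl carbon.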